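Compound 3 to compound 4: changing the chain group

The compounds below may be only part of what the source reports. "The series", "measured", "known", "first", "only" and "open" are said of these compounds alone.

Measured in a functional assay (trachea) with Cavia porcellus as the target; on this read-out lower numbers stand for stronger inhibition and higher numbers for weaker inhibition:
- compound 1 `CCn1nc(-c2cccnc2)c2ccccc2c1=O`: 1320 nM
- compound 2 `C=CCn1nc(-c2cccnc2)c2ccccc2c1=O`: 2140 nM
- compound 3 `O=c1c2ccccc2c(-c2cccnc2)nn1Cc1ccccc1`: 2450 nM

Compound 3 at 2450 nM stands within the scatter of both other compounds, so the three values give no order. Next is compound 4 `COCCn1nc(-c2cccnc2)c2ccccc2c1=O`, with methoxymethyl in place of phenyl on a saturated chain carbon bound to an aromatic nitrogen. Read one bond further out, this is benzyl to 2-methoxyethyl.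

All three measured steps change this same group, and all stay within the scatter: a 1.6-fold higher number from compound 1 to compound 2 (0.21 log units; within the scatter), a 1.9-fold higher number from compound 1 to compound 3 (0.27 log units; within the scatter) and a 1.1-fold higher number from compound 2 to compound 3 (0.06 log units; within the scatter). For the measured compounds named here, no measured compound carries methoxymethyl, so these steps are only indirect guidance. On that basis, no change beyond the scatter is expected in this assay. The expected size of the step is a 1.2-fold lower number from compound 3 to compound 4 (0.09 log units; within the scatter). For compound 4 the estimated value is 2000 nM, with an expected range of 800 nM to 5000 nM.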

Compound 4, half-maximal inhibitory concentration: 9330 nM
For compound 4 the middle estimate is 4.7-fold (0.67 log units) below the measured one, outside the stated range (above it).
By their numbers in this assay, from the lowest: compounds 1, 2 and 3 (each within the scatter of the next); then compound 4.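

Methoxymethyl in place of phenyl gives a 3.8-fold higher number from compound 3 to compound 4 (0.58 log units; beyond the scatter) in this assay and methoxymethyl in place of vinyl gives a 4.4-fold higher number from compound 2 to compound 4 (0.64 log units; beyond the scatter) so this position, flat across compounds 1, 2 and 3, does respond to the group it carries. Methoxy in place of hydrogen, on a saturated chain carbon two bonds along the chain from an aromatic nitrogen, gives the largest step of the set at a 7.1-fold higher number from compound 1 to compound 4 (0.85 log units; beyond the scatter) and this is the only change here that adds a hydrogen-bond acceptor to the chain. Nothing measured on these compounds accounts for the higher number.

Going by these compounds, whether the oxygen itself or the length of the chain goes with this step stays open. A plain propyl chain, or a hydroxyl or an amine in place of the methoxy, would separate these readings.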